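Dropping a Ring Methyl on a Shared Core

The compounds below may be only part of what the source reports. "The series", "measured", "known", "first", "only" and "open" are said of these compounds alone.

Compound 1, `CCc1nc(C)c2cnnc(SC)n12`: in a functional assay for inhibition, with Homo sapiens as the target (a higher number here means a weaker inhibitor, a lower number a stronger inhibitor), compound 1 gives > 48000 nM, which is a limit of the assay and not a number.
Compound 2, `CCCc1nc(C)c2cnnc(SC)n12`: in this assay compound 2 gives > 48000 nM, again a limit.
Compound 3, `CCCc1nc(C)c2c(C)nnc(SC)n12`: in this assay compound 3 gives > 48000 nM, again a limit.

Compound 2 therefore stands at the limit of the assay, with no exact value, and the other two measured compounds stand there as well. The step that the two limits leave unreadable from compound 1 to compound 2 and the step that the two limits leave unreadable from compound 2 to compound 3 cannot be read in size or direction because of the limit of > 48000 nM in this assay, at which 3 of the 3 values shown sit.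

Compound 4, `CCCc1ncc2cnnc(SC)n12`, differs from compound 2 by hydrogen in place of methyl on an aromatic carbon. The measured step that bears on this is a step that the two limits leave unreadable from compound 2 to compound 3, which concerns a methyl on an aromatic carbon, yet it remains unreadable. No direction or size can be expected for the change in this assay, and the most likely outcome is that compound 4 also ends at the limit. Compound 4 is therefore estimated at 60000 nM, between 25000 nM and 150000 nM. This corresponds to an expected step that the limit leaves unreadable from compound 2 to compound 4, nothing beyond the scatter.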

Compound 4, half-maximal inhibitory concentration: > 48000 nM
Compound 4 gave a limit, no number; the forecaster's own chance of this, stated with the estimate: 85%; the middle value is on the limit's open side.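

No new step can be read from compound 2 to compound 4, in size or direction, because both sit at the same limit of the assay: the limit of > 48000 nM in this assay, at which 4 of the 4 values shown sit.

The compounds shown leave open which change to the shared core, if any, would give an exact value in this assay at all.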